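The source may hold more compounds than are shown below. What is called first, only, known or untested is meant among the compounds shown, and "the series" means these compounds.

Measured compounds in an ADME assay on HEK-293T cells (Homo sapiens) for cytotoxicity, with a stated time of 48 h; on this read-out higher numbers stand for lower toxicity in this test and lower numbers for higher toxicity in this test:

Compound 1, `CCc1ncnc(NC(C)c2ccc(NC(C)=O)cc2)c1Cl`: > 10000 nM, a limit of the assay rather than a number.
Compound 2, `CCc1ncnc(NC(CC)c2ccc(Oc3ncnc4ccccc34)cc2)c1Cl`: > 10000 nM, likewise a limit of the assay.
Compound 3, `CCc1ncnc(NC(C)c2ccc3c(c2)CCCC3)c1Cl`: > 10000 nM, again a limit of the assay and not a number.

Compound 3 therefore stands where every measured compound of this set stands: at the upper limit of this assay, with no number of its own. The same holds for compound 1 and compound 2, so that the limit of > 10000 nM in this assay, at which 3 of the 3 values shown sit, sums up all that is known of the shared core here. Going by the values given here, no step between measured compounds can be read from these values, since none of them is a number.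

Compound 4, `CCc1ncnc(NC(C)c2cc3c(cc2O)CCCC3)c1Cl`, is the next compound to be tested in this assay. It differs from compound 3 in one place: hydroxy in place of hydrogen on an aromatic carbon. Among the compounds with values here, with all three measured compounds sitting at the limit, there is no measured step on which to build, and the change of hydroxy in place of hydrogen on an aromatic carbon gives no ground to expect a departure from that picture.

Compound 4 is accordingly expected to return a value around 15000 nM, within a range from 5000 nM to 50000 nM, most likely again reported as a limit. The expected step that the limit leaves unreadable from compound 3 to compound 4 is estimated to lie within the usual scatter, in no particular direction.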

Compound 4, half-maximal cytotoxic concentration: > 10000 nM
Compound 4 ended at the assay's limit; the forecaster's own chance of this, stated with the estimate: 80%; the middle value lies beyond the limit too.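

Compound 3 and compound 4 both sit at a limit of this assay rather than at a number, so no step between them can be read, and the hydroxy in place of hydrogen shows no measurable effect: the limit of > 10000 nM in this assay, at which 4 of the 4 values shown sit.

The compounds shown leave open how far beyond that limit each one lies, and which change to the shared core, if any, would bring a measurable value.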